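Swapping an Aryl Group for an Amine Chain

The source may hold more compounds than are shown below. What is called first, only, known or untested is meant among the compounds shown, and "the series" means these compounds.

Three compounds share one core. Compound 1 `C=CCn1c(=O)n(CCCCO)c2nc(N)nc(O)c21` gives 52 uM in a functional assay with Mus musculus as the target; a higher number here means that more compound is needed for the effect, a lower number that less compound is needed. Compound 2 `COc1ccc(Cn2c(=O)n(C3OC(CO)[C@@H](O)[C@H]3O)c3nc(N)nc(O)c32)cc1` gives 2 uM, and compound 3 `Nc1nc(O)c2c(n1)n(C1OC(CO)[C@@H](O)[C@H]1O)c(=O)n2Cc1ccc([N+](=O)[O-])cc1` gives 50 uM. Compound 3 therefore stands second highest of the three: its number lies within the scatter of compound 1, while compound 2 sits well lower. For the measured compounds named here, the only measured step, a 25-fold higher number from compound 2 to compound 3 (1.40 log units; beyond the scatter), exchanged one group for another on an aromatic carbon. Compound 4 `CN(C)CCCn1c(=O)n(C2OC(CO)[C@@H](O)[C@H]2O)c2nc(N)nc(O)c21` differs from compound 3 by 2-(dimethylamino)ethyl in place of 4-nitrophenyl on a saturated chain carbon bound to an aromatic nitrogen. Going by the values given here, no measured pair tests this kind of change; compound 1 carries a plain chain, but also a different second substituent, so it offers no clean comparison. Compound 4 is expected at an estimated 25 uM (range 4 uM to 150 uM). The expected step is a 2.0-fold lower number from compound 3 to compound 4 (0.30 log units; within the scatter), modest and uncertain in direction.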

Compound 4, concentration for half-maximal effect: 820 uM
The estimate for compound 4 lay 33-fold (1.52 log units) below the measured number; the measured number lies above the stated range.
By their numbers in this assay, from the lowest: compound 2; then compounds 3 and 1 (each within the scatter of the next); then compound 4.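

Putting 2-(dimethylamino)ethyl in place of 4-nitrophenyl on a saturated chain carbon bound to an aromatic nitrogen gives a 16-fold higher number from compound 3 to compound 4 (1.21 log units; beyond the scatter) in this assay and, in place of 4-methoxyphenyl, gives a 410-fold higher number from compound 2 to compound 4 (2.61 log units; beyond the scatter) as the second large step. The earlier step showed only a change on the aromatic ring, whereas these show that replacing the whole aryl group with this amine chain also moves the number strongly, and in the same direction from both aryl compounds. Nothing available explains this rise. As far as these compounds go, whether the ring's absence or the dimethylamino group matters more stays open. A plain unsubstituted benzyl group or a 3-hydroxypropyl chain at this place could help separate the two.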